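The source may report more compounds than this note shows. Statements on the series, on what has been measured and on what is new or still open speak of the compounds shown alone.

Working notes on the series around the core of compound 2 `O=S(=O)(NCCCNCc1ccc(C(F)(F)F)cc1)c1cc(C(F)(F)F)cc(C(F)(F)F)c1`. In a functional assay on BE(2)-C cells (Homo sapiens) for inhibition, read by MTT assay, with a stated time of 72 h (a higher number here means a weaker inhibitor of growth, a lower number a stronger inhibitor of growth), compound 2 gives 2700 nM, the second highest of the three numbers, though within the scatter of both others. Compound 1 `O=S(=O)(NCCCNCC1COc2ccccc2O1)c1cc(C(F)(F)F)cc(C(F)(F)F)c1` gives 2800 nM in this assay, and compound 3 `O=S(=O)(NCCCNCc1ccc(-c2ccccc2)cc1)c1cc(C(F)(F)F)cc(C(F)(F)F)c1` gives 2600 nM. Compound 4 `O=S(=O)(NCCCNCc1cccc(Cl)c1)c1cc(C(F)(F)F)cc(C(F)(F)F)c1` is not yet measured; it differs from compound 2 by 3-chlorophenyl in place of 4-(trifluoromethyl)phenyl on a saturated chain carbon bound to an amine nitrogen. Going by the values given here, two measured steps bear on changes at this position: a 1.0-fold lower number from compound 1 to compound 2 (0.02 log units; within the scatter) and a 1.0-fold lower number from compound 2 to compound 3 (0.02 log units; within the scatter); neither moved this assay beyond the scatter. On that basis compound 4 is expected to show no step beyond the scatter, no change at the digits printed from compound 2 to compound 4 (within the scatter). Compound 4 is accordingly estimated at 2700 nM, with a range from 1300 nM to 5600 nM.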

Compound 4, concentration for 50% growth inhibition: 6900 nM
Compound 4: middle estimate off by 2.6-fold (0.41 log units), on the low side; measured number outside the range, above it.
By their numbers in this assay, from the lowest: compounds 3, 2 and 1 (each within the scatter of the next); then compound 4.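

In this assay this position is no longer silent: a 2.6-fold higher number from compound 2 to compound 4 (0.41 log units; beyond the scatter) is a step beyond the scatter, with 3-chlorophenyl in place of 4-(trifluoromethyl)phenyl. The change from 2,3-dihydro-1,4-benzodioxin-2-yl to 3-chlorophenyl points the same way, a 2.5-fold higher number from compound 1 to compound 4 (0.39 log units; beyond the scatter), so the position does respond to the group it carries, though modestly. No measurement at hand accounts for these steps. The compounds shown leave open whether the chlorine or the trifluoromethyl group itself carries the step, and how a phenyl ring bearing an amine or a carboxylic acid would read.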